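The source may hold more compounds than are shown below. What is called first, only, known or untested is meant among the compounds shown, and "the series" means these compounds.

Measured so far in a functional assay on MDA-MB-231 cells (Homo sapiens) for inhibition, read by MTT assay, with a stated time of 48 h; a higher number here means a weaker inhibitor, a lower number a stronger inhibitor:
- compound 1 `COc1cc(-c2cc(-c3ccc(Br)cc3)nc(-c3ccccc3)n2)cc(OC)c1OC` gives only a limit, > 25000 nM
- compound 2 `COc1ccc(-c2cc(-c3cc(OC)c(OC)c(OC)c3)nc(-c3ccccc3)n2)cc1` gives 3390 nM
- compound 3 `COc1ccc(-c2cc(-c3cc(OC)c(OC)c(OC)c3)nc(-c3ccccc3)n2)c(OC)c1` gives 1440 nM

Compound 1 stands at the weak end: its value is a limit of this assay, not a number, at which one of the three values sits (the limit of > 25000 nM in this assay, at which 1 of the 3 values shown sits). Both replacements of its 4-bromophenyl improve matters: an at least 7.3-fold lower number from compound 1 to compound 2 (0.86 log units; beyond the scatter); an at least 17-fold lower number from compound 1 to compound 3 (1.23 log units; beyond the scatter). Between those two, a 2.4-fold lower number from compound 2 to compound 3 (0.37 log units; beyond the scatter).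

Compound 4 `COc1cc(-c2cc(-c3cccc([N+](=O)[O-])c3)nc(-c3ccccc3)n2)cc(OC)c1OC` carries the change (3-nitrophenyl in place of 4-bromophenyl on an aromatic carbon). The two measured steps from compound 1 bear on it only in that each swaps out the same 4-bromophenyl and each gives a lower number; neither introduces a 3-nitrophenyl, so the size of the step for compound 4 is uncertain. A lower number than the limit of compound 1 is expected, though a smaller drop than seen for compound 2 or compound 3 is assumed. The expected step is an at least 2.5-fold lower number from compound 1 to compound 4 (0.39 log units; beyond the scatter). Compound 4 is thus estimated at 10000 nM in this assay, within 2500 nM to 40000 nM, with a real chance that only a limit is returned.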

Compound 4, half-maximal inhibitory concentration: 2440 nM
For compound 4 the middle estimate is 4.1-fold (0.61 log units) above the measured one; the measured number lies below the stated range.
By their numbers in this assay, from the lowest: compounds 3, 4 and 2 (each within the scatter of the next, the first and the last beyond it). At a limit, above all of these: compound 1.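

In this assay, a third replacement of the 4-bromophenyl also gives a lower number, an at least 10-fold lower number from compound 1 to compound 4 (1.01 log units; beyond the scatter), and here the entering group, 3-nitrophenyl, carries no methoxy. Its result cannot be told apart from those of the two methoxy-bearing aryl groups: a 1.7-fold higher number from compound 3 to compound 4 (0.23 log units; within the scatter), and a 1.4-fold lower number from compound 2 to compound 4 (0.14 log units; within the scatter). A methoxy group is therefore not required at this position for a number in this range, and among the four compounds only compound 1 stands apart, though its value is a limit, so any step from it is only a bound: the limit of > 25000 nM in this assay, at which 1 of the 4 values shown sits.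

Still open, going by these compounds, is whether the place of the nitro on the phenyl matters, which a 4-nitrophenyl would show. On these data alone, it is equally open whether an amine or a carboxylic acid on that phenyl would keep the number in this range.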